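Replacing a tert-butylphenyl group in an oxidase inhibitor series

This account rests on a few compounds, and the source may have more. Where it says the series, first, only, none or still open, it means among the compounds named here.

Of the compounds shown here, three sharing one core have been tested in a functional assay on mitochondria from heart for inhibition of peroxisomal acyl-coenzyme A oxidase 1 (Rattus norvegicus); on this read-out higher numbers stand for weaker inhibition and lower numbers for stronger inhibition. Compound 1, `Cc1nc2cc(OC[C@H](O)CN3CCN(Cc4noc(-c5ccc(C(C)(C)C)cc5)n4)CC3)ccc2s1`, gives 180 nM in this assay. Compound 2, `Cc1nc2cc(OC[C@H](O)CN3CCN(Cc4nc(-c5ccc(C(C)(C)C)cc5)no4)CC3)ccc2s1`, gives 570 nM, and compound 3, `Cc1nc2cc(OC[C@H](O)CN3CCN(Cc4nc(-c5ccc(C(F)(F)F)cc5)sc4C)CC3)ccc2s1`, gives 1500 nM. Compound 1 therefore stands at the lowest number of the three, and both gaps to it lie beyond the usual scatter, so compound 1 is the strongest inhibitor among the measured compounds.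

The next compound, compound 4, `Cc1nc2cc(OC[C@H](O)CN3CCN(Cc4noc(-c5cccc(C#N)c5)n4)CC3)ccc2s1`, keeps the core of compound 1 and changes only the group on the five-membered aromatic ring: 3-cyanophenyl in place of 4-(tert-butyl)phenyl on an aromatic carbon. The 4-(tert-butyl)phenyl group leaves and a 3-cyanophenyl group, which brings one hydrogen-bond acceptor through its nitrile, enters.

Within the data shown here, no pair among the measured compounds differs at this position alone, so nothing measured tells how this exchange moves the number. Because compound 1 is the best measured point at 180 nM, a move upward is the more likely direction for compound 4, and a modest step beyond the scatter is expected, a 3.3-fold higher number from compound 1 to compound 4 (0.52 log units; beyond the scatter). Compound 4 is therefore estimated at 600 nM in this assay, with a range from 150 nM to 2500 nM.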

Compound 4, half-maximal inhibitory concentration: 13400 nM
The estimate for compound 4 lay 22-fold (1.35 log units) below the measured number; measured number above the stated range.
By their numbers in this assay, from the lowest: compound 1; then compound 2; then compound 3; then compound 4.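

In this assay, putting 3-cyanophenyl in place of 4-(tert-butyl)phenyl on this aromatic carbon gives a 74-fold higher number from compound 1 to compound 4 (1.87 log units; beyond the scatter), so the group at this position can make a large difference to the measured inhibition, which no earlier comparison could show. The exchange alters several things at once: the ring stays, but the tert-butyl group is lost, a nitrile arrives, and the point of attachment on the phenyl ring differs, so this single step cannot assign the loss to any one of these changes. No measurement shown here offers an explanation for the size of this step.

As far as these compounds go, it remains open whether the number rises mainly with the loss of the tert-butyl group or with the arrival of the nitrile, and whether other groups at this position would retain the inhibition of compound 1. A plain phenyl group on the same carbon would give a reference point for both substituents, and a phenyl group carrying an amine or a carboxylic acid would show how far this position tolerates quite different groups.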